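The compounds below may be only part of what the source reports. "The series", "measured", "known", "first", "only" and "open" are said of these compounds alone.

Measured so far:
compound 1, `Cc1occc1C(=O)N1CCC(NC(=O)Nc2ccc(OC(F)(F)F)cc2)CC1` — 4.3
compound 2, `CCOC(=O)N1CCC(NC(=O)Nc2ccc(OC(F)(F)F)c(F)c2)CC1` — 5.94
compound 3, `CC[C@H](C)C(=O)N1CCC(NC(=O)Nc2ccc(OC(F)(F)F)c(Cl)c2)CC1` — 7.7

In a physicochemical assay for lipophilicity, read by HPLC, with a stated time of 90 min, tested at 100 uM (on this read-out higher numbers stand for higher lipophilicity and lower numbers for lower lipophilicity), compound 1 gives the lowest of the three numbers. Compound 2 sits higher than compound 1, and compound 3 stands higher still, furthest from compound 1; both gaps are beyond the scatter. The new compound 4, `O=C(Nc1ccc(OC(F)(F)F)cc1)NC1CCN(C(=O)c2cc[nH]c2)CC1`, keeps the shared core of compound 1 and changes only one group, on a carbonyl carbon whose other neighbours are an amide-type nitrogen in a ring: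

1H-pyrrol-3-yl in place of 2-methylfuran-3-yl on a carbonyl carbon

Among the measured compounds shown here, no step between two measured compounds shows this change, so the expectation rests on the counted difference alone. Because compound 1 gives 4.3, compound 4 is expected to land lower, with a step of a number 1.00 log units lower from compound 1 to compound 4 (beyond the scatter) that is estimated to lie beyond the scatter. Compound 4 is thus expected at 3.3, within 2.6 to 4.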

Compound 4, partition coefficient: 3.34
Compound 4: the middle estimate sits 0.04 log units below what was measured; measured number inside the range.
By their numbers in this assay, from the lowest: compound 4; then compound 1; then compound 2; then compound 3.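

In this assay, the change on the carbonyl carbon gives a number 0.96 log units lower from compound 1 to compound 4 (beyond the scatter), which shows that this one group can by itself move the number beyond the scatter. The entering 1H-pyrrol-3-yl has 1 hydrogen-bond donor and 5 heavy atoms, while the leaving 2-methylfuran-3-yl has 1 hydrogen-bond acceptor and 6 heavy atoms. No measurement here explains the step.

Which of these differences matters remains open. So does how a furan-3-yl without its methyl, or a pyridine ring, would read on the same carbonyl carbon.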